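The source may report more compounds than this note shows. Statements on the series, on what has been measured and on what is new or still open speak of the compounds shown alone.

Compound 3 `CC1(C)C=C(n2ccccc2=O)c2cc(C(=O)c3ccccc3F)ccc2O1` gives 7.08 in a functional assay (aorta) with Rattus norvegicus as the target (on this read-out lower numbers stand for lower potency and higher numbers for higher potency (the scale is a negative logarithm)), the highest of the three numbers; compound 1 `CC1(C)C=C(n2ccccc2=O)c2cc(C(=O)c3ccccc3)ccc2O1` gives 6.61 and compound 2 `CC1(C)C=C(n2ccccc2=O)c2cc(C(=O)c3cccs3)ccc2O1` gives 6.4. The steps of a number 0.47 log units higher from compound 1 to compound 3 (beyond the scatter) and a number 0.68 log units higher from compound 2 to compound 3 (beyond the scatter) are modest, while a number 0.21 log units lower from compound 1 to compound 2 (within the scatter) stays within the scatter. Compound 4 `Cc1ccc(C)n1-c1ccc2c(c1)C(n1ccccc1=O)=CC(C)(C)O2` carries the change (2,5-dimethyl-1H-pyrrol-1-yl in place of (2-fluorophenyl)carbonyl on an aromatic carbon). For the measured compounds named here, none of the measured steps touches the carbonyl itself; each swaps one ring on the carbonyl carbon for another or puts fluoro on an aromatic carbon, so they bear only loosely on this change. With the (2-fluorophenyl)carbonyl gone, the gain seen in a number 0.47 log units higher from compound 1 to compound 3 (beyond the scatter) is expected to be lost and a fall somewhat beyond the scatter is estimated, a number 0.68 log units lower from compound 3 to compound 4 (beyond the scatter). Compound 4 is expected to give 6.4, within 5.6 to 7.1.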

Compound 4, logarithm of the reciprocal of the active concentration, log(1/C): 7.27
Beside the measured number, compound 4's estimate is 0.87 log units below it, outside the stated range (above it).
By their numbers in this assay, from the lowest: compounds 2 and 1 (each within the scatter of the next); then compounds 3 and 4 (each within the scatter of the next).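

At this aromatic carbon, in this assay, a carbonyl link to the ring is not required: 2,5-dimethyl-1H-pyrrol-1-yl, which has no carbonyl, is not separated from (2-fluorophenyl)carbonyl (a number 0.19 log units higher from compound 3 to compound 4 (within the scatter)). The same group stands clear of both other acyl groups (a number 0.87 log units higher from compound 2 to compound 4 (beyond the scatter); a number 0.66 log units higher from compound 1 to compound 4 (beyond the scatter)). Nothing available gives a reason for this result.

Open is whether the two methyl groups on the pyrrole contribute, since the unsubstituted pyrrol-1-yl is not among these compounds. Also open, as far as these compounds go, is how a small non-aromatic group, such as a nitrile or an amine, would read at this carbon.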